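Methyl to cyanovinyl on the phenyl: expected cell tolerance

The source may report more compounds than this note shows. Statements on the series, on what has been measured and on what is new or still open speak of the compounds shown alone.

Compound 1 `Cc1cc(C)cc(Oc2cc(Cl)nc(NCCn3ccc(=O)[nH]c3=O)n2)c1` gives in an ADME assay on MT4 cells (Homo sapiens) for cytotoxicity, read by MTT assay, with a stated time of 5 days (a higher number here means that more compound is tolerated, a lower number that less compound is tolerated), only a limit, > 56400 nM. Compound 2 `Cc1cc(C)c(Oc2cc(Cl)nc(NCCn3ccc(=O)[nH]c3=O)n2)c(C)c1` gives 44100 nM. Compound 3 `Cc1cc(C)c(Oc2ccnc(NCCn3ccc(=O)[nH]c3=O)n2)c(C)c1` gives 272000 nM.

Among the two actual numbers compound 2 stands lowest, with compound 3 a 6.2-fold higher number from compound 2 to compound 3 (0.79 log units; beyond the scatter) away; the other value is a limit (the limit of > 56400 nM in this assay, at which 1 of the 3 values shown sits). Compound 4 `Cc1cc(/C=C/C#N)cc(C)c1Oc1cc(Cl)nc(NCCn2ccc(=O)[nH]c2=O)n1` differs from compound 2 by 2-cyanoethenyl in place of methyl on an aromatic carbon. Neither measured step touches a 2-cyanoethenyl group: an at least 1.2-fold lower number from compound 1 to compound 2 (0.10 log units; that floor lies within the scatter) rearranged methyls on the same ring and stayed within the scatter, while a 6.2-fold higher number from compound 2 to compound 3 (0.79 log units; beyond the scatter) removed a chloro on the other ring. Among the measured compounds shown here, with no step that bears directly on this change, compound 4 is expected to give a number close to compound 2, with a 1.5-fold lower number from compound 2 to compound 4 (0.17 log units; within the scatter). Compound 4 is therefore estimated at 30000 nM, in the range 8000 nM to 150000 nM.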

Compound 4, half-maximal cytotoxic concentration: > 284000 nM
Compound 4: a limit, no number (the forecaster's own chance of this, stated with the estimate: 20%); at least 9.4-fold (0.97 log units) between middle value and limit.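

Putting 2-cyanoethenyl in place of methyl on the aromatic carbon para to a large group gives an at least 6.4-fold higher number from compound 2 to compound 4 (0.80 log units; beyond the scatter) in this assay. Among the compounds shown here, this position therefore takes a larger group with no loss of cell tolerance, and the earlier steps, which never changed this group, could not show that. Compound 4 gives only a limit, not a number, so the full size of the step remains unknown: the limit of > 284000 nM in this assay, at which 1 of the 4 values shown sits.

The compounds shown leave open whether the nitrile, the double bond or simply the longer chain accounts for the step. A saturated cyanoethyl chain or a carboxylic acid at this position would help separate these.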